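The compounds below may be only part of what the source reports. "The series", "measured", "known", "first", "only" and "open" are said of these compounds alone.

In a functional assay on HL-60 cells (Homo sapiens) for cytotoxicity, read by MTT assay, with a stated time of 3 days (a higher number here means a weaker inhibitor, a lower number a stronger inhibitor), three compounds built on one shared core have been measured: compound 1 `N#Cc1c(O)nc(SCc2nc3ccccc3[nH]2)nc1-c1ccccc1` gives 2.55 nM, compound 2 `CNc1nc(SCc2nc3ccccc3[nH]2)nc(-c2ccccc2)c1C#N` gives 6.57 nM, and compound 3 `CCNc1nc(SCc2nc3ccccc3[nH]2)nc(-c2ccccc2)c1C#N` gives 3.96 nM. Compound 3 stands within the scatter of both others, as the steps show: a 1.6-fold higher number from compound 1 to compound 3 (0.19 log units; within the scatter) and a 1.7-fold lower number from compound 2 to compound 3 (0.22 log units; within the scatter). Compound 4 `N#Cc1c(Nc2nccs2)nc(SCc2nc3ccccc3[nH]2)nc1-c1ccccc1` has 1,3-thiazol-2-yl in place of ethyl on a nitrogen on an aromatic ring. Within the data shown here, the only step beyond the scatter is modest: a 2.6-fold higher number from compound 1 to compound 2 (0.41 log units; beyond the scatter). Among the measured compounds shown here, no measured compound carries a ring on this nitrogen, so the data give no direction, and no step beyond the scatter is expected. The expected change is a 1.3-fold higher number from compound 3 to compound 4 (0.10 log units; within the scatter). For compound 4 the estimate is 5 nM, with an expected range of 1.5 nM to 18 nM.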

Compound 4, half-maximal inhibitory concentration: 11.9 nM
The estimate for compound 4 lay 2.4-fold (0.38 log units) below the measured number; measured number inside the range.
By their numbers in this assay, from the lowest: compounds 1, 3, 2 and 4 (each within the scatter of the next, the first and the last beyond it).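

Compound 4 is the only compound shown with a ring on this nitrogen, and in this assay 1,3-thiazol-2-yl in place of ethyl gives a modest step beyond the scatter (a 3.0-fold higher number from compound 3 to compound 4 (0.48 log units; beyond the scatter)). In place of methyl, the same ring stays within the scatter (a 1.8-fold higher number from compound 2 to compound 4 (0.26 log units; within the scatter)), whereas (1,3-thiazol-2-yl)amino in place of hydroxy gives a modest step beyond it (a 4.7-fold higher number from compound 1 to compound 4 (0.67 log units; beyond the scatter)). No evidence here explains these steps. The compounds shown leave open how a phenyl ring or a longer chain such as propyl on this nitrogen would compare.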